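One Group Swapped on an Aromatic Ring

The compounds below may be only part of what the source reports. "The series", "measured", "known", "first", "only" and "open" are said of these compounds alone.

Of the compounds shown here, two sharing a core have been tested so far. In a functional assay on J774 cells (Mus musculus) for cytotoxicity, read by resazurin assay (a lower number here means a stronger inhibitor, a higher number a weaker inhibitor), compound 1 `OCCCCCC(O)c1ccc(-c2ccccc2F)cc1` gives 22000 nM and compound 2 `CSc1ccc(-c2ccc(C(O)CCCCCO)cc2)cc1` gives 24000 nM as its half-maximal inhibitory concentration. These two numbers lie within the usual scatter of repeated measurements, so compound 2 stands level with compound 1 and neither can be called the stronger inhibitor.

The next compound, compound 3 `OCCCCCC(O)c1ccc(-c2ccc(Cl)cc2)cc1`, has not yet been measured. It differs from compound 2 in one place, with chloro in place of methylsulfanyl on an aromatic carbon, para to a large group chloro in place of methylsulfanyl on an aromatic carbon in the counted terms.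

Among the measured compounds shown here, no measured pair shows what this exchange does by itself, so any forecast is rough. For the measured compounds named here, the only guide is that compound 1 at 22000 nM and compound 2 at 24000 nM sit within the scatter of each other, and no step beyond the scatter is expected in this assay here. The estimated change is a 1.1-fold lower number from compound 2 to compound 3 (0.04 log units; within the scatter) and it is expected to stay within the scatter. In this assay the estimate for compound 3 is 22000 nM with an expected range from 11000 nM to 45000 nM for repeat measurements.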

Compound 3, half-maximal inhibitory concentration: 17000 nM
Compound 3: the middle estimate sits 1.3-fold (0.11 log units) above what was measured, within the range that was stated.
By their numbers in this assay, from the lowest: compounds 3, 1 and 2 (each within the scatter of the next).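

In this assay, chloro in place of methylsulfanyl on an aromatic carbon, para to a large group, gives a 1.4-fold lower number from compound 2 to compound 3 (0.15 log units; within the scatter) and so leaves the two compounds level. Among the compounds shown here, this is the first exchange read at this position on its own: one hydrogen-bond acceptor and one heavy atom are lost with no step beyond the scatter, and a 1.3-fold lower number from compound 1 to compound 3 (0.11 log units; within the scatter) likewise stays level when 4-chlorophenyl stands in place of 2-fluorophenyl. No supporting measurement is available to explain why these numbers stay together.

The compounds shown leave open whether any group at this position can move the number beyond the scatter, as an amine, a carboxylic acid or a longer chain in place of chloro might or might not do. They also leave open what a change elsewhere on the shared core would do, since all three compounds keep that core and differ only in the substituents named here.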